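The source may hold more compounds than are shown below. What is called first, only, known or untested is meant among the compounds shown, and "the series" means these compounds.

Working notes on the series.

Three compounds share the core of compound 1, `CCCCCN(CCCCC)C(=O)N1CCN(C(=O)N(c2ccccc2)c2ccccc2)[C@H](C(=O)O)C1`, and have numbers in an assay for inhibition of Type-2 angiotensin II receptor (Rattus norvegicus); on this read-out higher numbers stand for weaker inhibition and lower numbers for stronger inhibition. Compound 1 gives 1.4 nM, the lowest number among the three, so it shows the strongest inhibition in the set. Among the measured compounds shown here, compound 2, `CN(C(=O)N1CCN(C(=O)N(c2ccccc2)c2ccccc2)[C@H](C(=O)O)C1)c1ccccc1`, gives 170 nM; the one-place step a 120-fold higher number from compound 1 to compound 2 (2.08 log units; beyond the scatter) is the only measured step in the set and concerns the urea amine, not the diphenylamino side. Compound 3, `CC1CN(C(=O)N(c2ccccc2)c2ccccc2)CCN1C(=O)N(c1ccccc1)c1ccccc1`, gives 15 nM, a higher number than compound 1, but it differs from compound 1 in more than one place and no single step can be read from the pair.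

Compound 4, `CCCCCN(CCCCC)C(=O)N1CCN(C(=O)N(c2ccccc2)c2ccc(C(=O)O)cc2)[C@H](C(=O)O)C1`, is not yet measured. It differs from compound 1 by carboxy in place of hydrogen on an aromatic carbon, read one bond further out as phenyl to 4-carboxyphenyl. For the measured compounds named here, no measured step touches this ring, so nothing in the data sets a direction for this change; the expectation is therefore a small shift, most likely toward a somewhat higher number, with wide uncertainty. For compound 4 the estimated step from compound 1 is a 2.1-fold higher number from compound 1 to compound 4 (0.33 log units; beyond the scatter). Compound 4 is expected to give about 3 nM in this assay, with a likely range from 0.6 nM to 15 nM.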

Compound 4, half-maximal inhibitory concentration: 180 nM
For compound 4 the middle estimate is 60-fold (1.78 log units) below the measured one; measured number above the stated range.
By their numbers in this assay, from the lowest: compound 1; then compound 3; then compounds 2 and 4 (each within the scatter of the next).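

In this assay, among the compounds shown here, the change from phenyl to 4-carboxyphenyl gives a 130-fold higher number from compound 1 to compound 4 (2.11 log units; beyond the scatter), so this aromatic carbon, on a ring where no step had been measured before, is far from indifferent to what it carries. The low number of compound 1 therefore depends on more than the urea amine: alongside a 120-fold higher number from compound 1 to compound 2 (2.08 log units; beyond the scatter), a single change at either of two separate places is now enough to give a large step. No supporting data bear on why adding carboxy has this outcome, so the step stands as an observation only.

The compounds shown leave open whether the step belongs to carboxy itself or to any added group at this place, as a methyl ester, a primary amide or a single chlorine at the same carbon would help to show. They also leave open how the same carboxy would read on the other phenyl ring of the diphenylamino group, or on compound 2, which carries methyl(phenyl)amino in place of dipentylamino.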